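A few compounds are considered here, and "the series" means these few. Any claim that something is new, unique, unknown or untested is made for them only; others in the source may bear on it.

Of the compounds shown here, three that share one core have been tested in a functional assay on T-24 cells (Homo sapiens) for cytotoxicity, read by CCK-8 assay, with a stated time of 24 h; on this read-out higher numbers stand for weaker inhibition and lower numbers for stronger inhibition. Compound 1 `C/C(=C\c1cc(-c2ccc(C)cc2)co1)C(N)=O` gives only a limit of the assay there, > 50000 nM. Compound 2 `C/C(=C\c1cc(-c2ccccc2)cs1)C(N)=O` also gives only a limit, > 50000 nM. Compound 3 `C/C(=C\c1cc(-c2ccc(C#N)cc2)cs1)C(N)=O` stands in the same place, giving only a limit, > 50000 nM. The one step among these compounds that differs in a single place, a step that the two limits leave unreadable from compound 2 to compound 3, cannot be sized because both of its values sit at the limit of > 50000 nM in this assay, at which 3 of the 3 values shown sit.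

Compound 4 `C/C(=C\c1cc(-c2ccc(C(F)(F)F)cc2)cs1)C(N)=O` differs from compound 3 in one place: trifluoromethyl in place of cyano on an aromatic carbon. Among the measured compounds shown here, the only measured step that bears on a change at this aromatic carbon is the one from compound 2 to compound 3, and its size is unreadable, so no direction of change can be taken from it. For the measured compounds named here, with every value so far resting at the limit, the most that can be expected is that compound 4 also stays at or beyond it.

Compound 4 is therefore expected to give 60000 nM in this assay, within a range from 15000 nM to 300000 nM. The expected step, a step that the limit leaves unreadable from compound 3 to compound 4, is none beyond the scatter, and the outcome is expected most likely to be reported as a limit rather than a number.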

Compound 4, half-maximal inhibitory concentration: > 50000 nM
Compound 4 gave a limit, no number; the forecaster's own chance of this, stated with the estimate: 80%; the middle value does not contradict the limit.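

The steps to compound 4 from compound 2 and from compound 3 cannot be read, because all of these results are limits rather than numbers: the limit of > 50000 nM in this assay, at which 4 of the 4 values shown sit. The compounds shown leave open how cyano, trifluoromethyl and hydrogen at this aromatic carbon truly compare in this assay.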